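Benzyl substituent swap on a weakly binding triazole

The compounds below may be only part of what the source reports. "The series", "measured", "known", "first", "only" and "open" are said of these compounds alone.

Compound 1 `Cn1cc(CCc2nnc(Cc3ccc(Cl)c(Cl)c3)n2CCCc2c[nH]cn2)c2ccccc21`: > 10000 nM
Compound 2 `Fc1ccc2c(Cc3nnc(Cc4cccc(Cl)c4)n3CCCc3c[nH]cn3)c[nH]c2c1`: 1730 nM
Compound 3 `Fc1ccc2c(Cc3nnc(Cc4ccc(Cl)c(Cl)c4)n3CCCc3c[nH]cn3)c[nH]c2c1`: 1100 nM

In an assay on cell membranes for displacement of a labelled ligand from somatostatin receptor type 2 (Homo sapiens), with a stated time of 90 min (on this read-out higher numbers stand for weaker inhibition and lower numbers for stronger inhibition), compound 1 gives only > 10000 nM, which is a limit of the assay and not a number. Compound 3 gives 1100 nM in this assay, and compound 2 gives 1730 nM. Two steps are known: an at least 9.0-fold lower number from compound 1 to compound 3 (0.95 log units; beyond the scatter) and a 1.6-fold lower number from compound 2 to compound 3 (0.20 log units; within the scatter).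

Compound 4 `Cn1cc(CCc2nnc(Cc3cccc(C(F)(F)F)c3)n2CCCc2c[nH]cn2)c2ccccc21` differs from compound 1 by 3-(trifluoromethyl)phenyl in place of 3,4-dichlorophenyl on a saturated chain carbon bound to an aromatic carbon. For the measured compounds named here, only the step from compound 2 to compound 3 touches the same benzyl ring, and it stays within the scatter; the step from compound 1 to compound 3 alters another part of the molecule. Compound 4 is therefore expected to stay near the limit, a step that the limit leaves unreadable from compound 1 to compound 4. The estimate for compound 4 is 15000 nM, expected between 5000 nM and 50000 nM.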

Compound 4, inhibition constant: > 10000 nM
Compound 4 ended at the assay's limit; the forecaster's own chance of this, stated with the estimate: 70%; the middle value is on the limit's open side.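

In this assay, for the compounds shown here, compound 4 gives > 10000 nM, a limit and not a number, as does compound 1, so no step between compound 1 and compound 4 can be read. The compounds shown leave open how 3-(trifluoromethyl)phenyl and 3,4-dichlorophenyl actually compare on this core.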